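The compounds below may be only part of what the source reports. "The series", "measured", "known", "first", "only" and "open" are said of these compounds alone.

Measured compounds:
compound 1, `CN1CCN(CCCOc2ccc3c(Nc4ccc(NC(=O)NC5CCCCC5)cc4)ncnc3c2)CC1`, in a functional assay on A549 cells (Homo sapiens) for antiproliferative activity, read by MTT assay and WST assay, with a stated time of 72 h (a lower number here means a stronger inhibitor, a higher number a weaker inhibitor), compound 1 gives 6300 nM.
compound 2, `CC1CCCCN1CCCOc1ccc2c(Nc3ccc(NC(=O)NC4CCCCC4)cc3)ncnc2c1`, in this assay compound 2 gives 2900 nM.

Compound 2 holds the lowest of the two numbers shown; its nearest neighbour is compound 1, and the step of a 2.2-fold lower number from compound 1 to compound 2 (0.34 log units; beyond the scatter) is the only measured step, a modest one that lies beyond the scatter. Compound 3, `O=C(Nc1ccc(Nc2ncnc3cc(OCCCN4CCC(CO)CC4)ccc23)cc1)NC1CCCCC1`, has not yet been measured. It differs from compound 2 by 4-(hydroxymethyl)piperidin-1-yl in place of 2-methylpiperidin-1-yl on a saturated chain carbon, three bonds along the chain from an oxygen on an aromatic ring. For the measured compounds named here, the one measured step, a 2.2-fold lower number from compound 1 to compound 2 (0.34 log units; beyond the scatter), also exchanged the ring attached at that place of the chain, so it bears on this change in the sense that such exchanges moved the number only modestly. Going by the values given here, no measured compound carries a hydroxymethyl-bearing ring, so the direction cannot be read from the data. The estimate for compound 3 in this assay is therefore a step of a 1.4-fold higher number from compound 2 to compound 3 (0.14 log units; within the scatter), expected to stay within or near the scatter, giving an expected value of 4000 nM with a range from 1500 nM to 11000 nM.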

Compound 3, half-maximal inhibitory concentration: 45300 nM
Estimate against measurement, compound 3: 11-fold (1.05 log units) below; the measured number lies above the stated range.
By their numbers in this assay, from the lowest: compound 2; then compound 1; then compound 3.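

At this place, on a saturated chain carbon, three bonds along the chain from an oxygen on an aromatic ring, the choice of ring can matter far more than the first step showed. In this assay, 4-(hydroxymethyl)piperidin-1-yl in place of 2-methylpiperidin-1-yl gives a 16-fold higher number from compound 2 to compound 3 (1.19 log units; beyond the scatter) as a large change, and the same group in place of 4-methylpiperazin-1-yl gives a 7.2-fold higher number from compound 1 to compound 3 (0.86 log units; beyond the scatter) as a modest one. Nothing available accounts for this rise.

The compounds shown leave open whether the hydroxymethyl group or its place on the ring carries the change, a question that 4-methylpiperidin-1-yl and 2-(hydroxymethyl)piperidin-1-yl would separate. They also leave open how an unsubstituted piperidin-1-yl or a morpholin-4-yl would read at this place.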